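Aryl in place of methyl on the five-membered ring

The compounds below may be only part of what the source reports. "The series", "measured", "known", "first", "only" and "open" are said of these compounds alone.

Three compounds of the series carry numbers in a functional assay on ACHN cells (Homo sapiens) for cytotoxicity, read by sulforhodamine B assay, tested at 10 uM; on this read-out lower numbers stand for less inhibition and higher numbers for more inhibition at the one concentration tested (going by the name of the read-out). Compound 1 `CCCc1cc(-c2cn([C@H]3C[C@H](OC(C)=O)[C@@H](COC(C)=O)O3)c(=O)[nH]c2=O)on1` gives 99.5%. Compound 2 `CC(=O)OC[C@H]1O[C@@H](n2cc(-c3cc(-c4ccc(C(C)(C)C)cc4)no3)c(=O)[nH]c2=O)C[C@@H]1OC(C)=O` gives 74.7%. Compound 3 `CC(=O)OC[C@H]1O[C@@H](n2cc(-c3cc(C)no3)c(=O)[nH]c2=O)C[C@@H]1OC(C)=O` gives 96.4%, the second highest of the three; its gap to compound 1 lies within the scatter, while against compound 2 the step is a number 21.7 percentage points higher from compound 2 to compound 3 (beyond the scatter). The second step touching an aryl group at the same place is a number 24.8 percentage points lower from compound 1 to compound 2 (beyond the scatter).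

Compound 4 `CC(=O)OC[C@H]1O[C@@H](n2cc(-c3cc(-c4ccc(C(C)C)cc4)no3)c(=O)[nH]c2=O)C[C@@H]1OC(C)=O` is not yet measured. It differs from compound 3 by 4-isopropylphenyl in place of methyl on an aromatic carbon. The entering 4-isopropylphenyl group is close in kind to the 4-(tert-butyl)phenyl group of compound 2, and both steps that put that aryl group in or took it out were modest and beyond the scatter. The step from compound 3 to compound 4 is therefore expected to be a modest loss, about a number 18.4 percentage points lower from compound 3 to compound 4 (beyond the scatter), because of a number 21.7 percentage points higher from compound 2 to compound 3 (beyond the scatter) read in reverse. Compound 4 is estimated at 78%, with an expected range from 62% to 93%.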

Compound 4, a percentage reported as inhibition, at one concentration (the size of the read-out at that concentration, not a potency): 90.1%
Compound 4: middle estimate off by 12.1 percentage points, on the low side; the measured number falls inside the stated range.
By their numbers in this assay, from the lowest: compound 2; then compounds 4, 3 and 1 (each within the scatter of the next).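

In this assay, an aryl group at this place on the five-membered ring does not in itself bring a step beyond the scatter: 4-isopropylphenyl in place of methyl gives a number 6.3 percentage points lower from compound 3 to compound 4 (within the scatter), and 4-isopropylphenyl in place of propyl gives a number 9.4 percentage points lower from compound 1 to compound 4 (within the scatter). Compound 2 goes against any reading of aryl groups as a single class, and the change that separates it from the isopropyl analogue is small: hydrogen in place of one methyl of the 4-(tert-butyl)phenyl group gives a number 15.4 percentage points higher from compound 2 to compound 4 (beyond the scatter). No measurement on hand explains this difference.

Going by these compounds, all four compounds are read at one concentration, so any separation among compound 1, compound 3 and compound 4 at lower concentrations remains open. Also open, on these data alone, is how a 4-aminophenyl or 4-carboxyphenyl group would read at this place.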